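Thiosemicarbazone series on Bel-7402 cells: benzyl isothiosemicarbazide exchange

The source may report more compounds than this note shows. Statements on the series, on what has been measured and on what is new or still open speak of the compounds shown alone.

Working notes on a small set of pyrimidinone thiosemicarbazones tested in a functional assay on Bel-7402 cells (Homo sapiens) for antiproliferative activity, read by MTT assay, with a stated time of 72 h; on this read-out higher numbers stand for weaker inhibition and lower numbers for stronger inhibition.

Compound 1 `NC(=S)N/N=C1/C=C(Nc2ccc(Cl)cc2)C(Nc2ccc(Cl)cc2)=NC1=O` carries two chloroanilino groups on the core and a thiosemicarbazone side chain. In this assay compound 1 gives 820 nM. Compound 2 `COc1ccccc1NC1=C/C(=N/NC(N)=S)C(=O)N=C1Nc1ccccc1OC` has two methoxyanilino groups in place of the chloroanilino groups; how the two cores differ is not broken down here. In this assay compound 2 gives 13400 nM, a far higher number than compound 1.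

Compound 3 `N/C(=N\N=C1\C=C(Nc2ccc(Cl)cc2)C(Nc2ccc(Cl)cc2)=NC1=O)SCc1ccccc1` is compound 1 with the side chain altered: a group of 11 heavy atoms (8 carbon, 2 nitrogen, 1 sulfur; one six-membered aromatic ring of carbon only) in place of a group of 4 heavy atoms (1 carbon, 2 nitrogen, 1 sulfur; no ring), on a double-bonded nitrogen. This change produced a 21-fold higher number from compound 1 to compound 3 (1.32 log units; beyond the scatter), so in this assay compound 3 gives 17300 nM. The numbers for compound 2 and compound 3 lie within the scatter of each other, and nothing about order can be said between them.

Compound 4 `COc1ccccc1NC1=C/C(=N/N=C(\N)SCc2ccccc2)C(=O)N=C1Nc1ccccc1OC`, not yet measured, is compound 2 with the same change: a group of 11 heavy atoms (8 carbon, 2 nitrogen, 1 sulfur; one six-membered aromatic ring of carbon only) in place of a group of 4 heavy atoms (1 carbon, 2 nitrogen, 1 sulfur; no ring), on a double-bonded nitrogen. The surroundings of the place are the same in both pairs, so this is the same change made on the core of compound 2 rather than on the core of compound 1.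

Among the measured compounds shown here, the only guide is the single measured step of this change. If it carries over, compound 4 is expected to show a step of about a 9.0-fold higher number from compound 2 to compound 4 (0.95 log units; beyond the scatter) from compound 2, resting on the step from compound 1 to compound 3 of a 21-fold higher number from compound 1 to compound 3 (1.32 log units; beyond the scatter). Because compound 2 already gives 13400 nM, the expected number for compound 4 would sit very high. The estimate for compound 4 in this assay is 120000 nM, with a range from 30000 nM to 400000 nM.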

Compound 4, half-maximal inhibitory concentration: 13100 nM
For compound 4 the middle estimate is 9.2-fold (0.96 log units) above the measured one; measured number below the stated range.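

In this assay the exchange of the thiosemicarbazone side chain for the benzyl isothiosemicarbazide side chain gives a 1.0-fold lower number from compound 2 to compound 4 (0.01 log units; within the scatter), so on this core the change leaves no readable difference. Set beside the earlier step, the same change does not carry over from one core to the other in this pair of cores: the same change on two cores in this assay, a 21-fold higher number (1.32 log units; beyond the scatter) from compound 1 to compound 3 and a 1.0-fold lower number (0.01 log units; within the scatter) from compound 2 to compound 4, 22-fold (1.33 log units) apart, beyond the scatter of two such steps. This shows that the step measured on one core cannot be transferred as a fixed increment to the other, but it does not show which part of the difference between the chloroanilino and methoxyanilino groups sets the two steps apart, and two pairs give no rule for a third core.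

Still open, as far as these compounds go, is which of the two steps is the more typical one for the series, a question that a third core, for instance one with plain anilino or fluoroanilino groups, would begin to address. Also open, from the compounds shown here alone, is how either core responds when a methyl group or a longer chain stands in place of the benzyl group in the side chain.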